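A few compounds are considered here, and "the series" means these few. Any claim that something is new, unique, unknown or untested is made for them only; others in the source may bear on it.

Of the compounds shown here, three built on one shared core have been tested in a functional assay, read by spectrophotometry, with a stated time of 15 min, tested at 40 ug/mL; on this read-out lower numbers stand for a weaker effect and higher numbers for a stronger effect at the one concentration tested. Compound 1 `COC(=O)c1cc(-c2csc(N/N=C/c3cccs3)n2)ccc1OCc1ccccc1` gives 82.8% in this assay. Compound 2 `Clc1ccc(-c2csc(N/N=C/c3cccs3)n2)cc1` gives 83.2% in this assay. Compound 3 `Cc1ccc(-c2csc(N/N=C/c3ccc(Cl)cc3Cl)n2)cc1` gives 80.4% in this assay. The gaps separating compound 3 from compound 1 and from compound 2 both lie within the usual scatter of repeated measurements, so the three numbers stand level and nothing can be read into their order; each compound shows a strong effect at the one concentration tested, whatever groups it carries on its outer rings.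

Compound 4 `Clc1ccc(-c2csc(N/N=C/c3ccc(Cl)cc3Cl)n2)cc1` has not yet been measured. It differs from compound 3 in a single place: chloro in place of methyl on an aromatic carbon. Cut one bond further out, the same change reads 4-methylphenyl to 4-chlorophenyl. For the measured compounds named here, no measured pair in this set isolates such a swap, so the only guide is that every compound tested so far falls in the same narrow band of this assay. The step from compound 3 to compound 4 in this assay is therefore expected to be a number 1.6 percentage points higher from compound 3 to compound 4 (within the scatter), which is none beyond the scatter. Compound 4 is estimated at 82% in this assay, with a range from 70% to 91%.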

Compound 4, a percentage reported as inhibition, at one concentration (the size of the read-out at that concentration, not a potency): 76.2%
For compound 4 the middle estimate is 5.8 percentage points above the measured one; the measured number falls inside the stated range.
By their numbers in this assay, from the lowest: compounds 4, 3, 1 and 2 (each within the scatter of the next).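

For the compounds shown here, this pair is the first in the set to change one group alone, so it gives the first direct look at this position: with chloro in place of methyl on an aromatic carbon, para to a large group, this assay shows a number 4.2 percentage points lower from compound 3 to compound 4 (within the scatter). The earlier compounds shown here differed in more than one place and could not separate this swap from other changes, whereas here the rest of the structure stays fixed and compound 3 and compound 4 stand level, so the read-out at the one concentration tested does not tell methyl from chloro at this position. Nothing available explains this result or links it to any property of either group.

The compounds shown leave open whether this position would stay level with a very different group on the same carbon, such as an amine, a carboxylic acid or a longer chain. Going by these compounds alone, they also leave open whether the same swap would give a similar step with the thiophene-bearing side of compound 2 in place of the dichlorophenyl side, and a single concentration gives no potency for either compound.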